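A few compounds are considered here, and "the series" means these few. Any claim that something is new, unique, unknown or untested is made for them only; others in the source may bear on it.

Every number here comes from a functional assay on MCF7 cells (Homo sapiens) for inhibition, read by MTT assay, with a stated time of 48 h (a higher number here means a weaker inhibitor, a lower number a stronger inhibitor), which reports how much of a compound is needed to inhibit the growth of a human breast-cancer cell line over the stated time. Among the measured compounds shown here, compound 1 `O=[N+]([O-])c1ccc2[nH]cc(C(c3ccc(Cl)cc3)c3c[nH]c4ccc([N+](=O)[O-])cc34)c2c1` is the first of two close relatives. In this assay compound 1 gives > 100000 nM, which is a limit of the assay rather than a number. Compound 2 `O=[N+]([O-])c1ccc2[nH]cc(C(c3ccc(Br)cc3)c3c[nH]c4ccc([N+](=O)[O-])cc34)c2c1` is the second relative. In this assay compound 2 gives > 100000 nM, again a limit and not a number. The two differ only in bromo in place of chloro on an aromatic carbon. The resulting step that the two limits leave unreadable from compound 1 to compound 2 cannot be read because of the limit of > 100000 nM in this assay, at which 2 of the 3 values shown sit.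

Compound 3 `OC[C@H]1O[C@@H](n2cc(C(c3ccc(Cl)cc3)c3cn([C@@H]4O[C@H](CO)[C@@H](O)[C@H](O)[C@H]4O)c4ccc(Br)cc34)c3cc(Br)ccc32)[C@H](O)[C@@H](O)[C@@H]1O` is built on a different core; the difference between the two cores is not broken down here. In this assay, for the measured compounds named here, compound 3 gives 53200 nM, the only full number in the set so far.

Compound 4 `OC[C@H]1O[C@@H](n2cc(C(c3ccc(Br)cc3)c3cn([C@@H]4O[C@H](CO)[C@@H](O)[C@H](O)[C@H]4O)c4ccc(Br)cc34)c3cc(Br)ccc32)[C@H](O)[C@@H](O)[C@@H]1O` has not yet been measured. Going by the values given here, it differs from compound 3 by bromo in place of chloro on an aromatic carbon, the same change as the one between compound 1 and compound 2, at the same place. The earlier step that the two limits leave unreadable from compound 1 to compound 2 gives no readable size, so the expectation rests on compound 3 with its value 53200 nM and on the fact that the change swaps a single heavy atom for another. For compound 4 the expected step is a 1.0-fold higher number from compound 3 to compound 4 (0.01 log units; within the scatter), small enough to sit within the usual scatter. Compound 4 is therefore estimated to give 55000 nM, with a likely range from 25000 nM to 120000 nM.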

Compound 4, half-maximal inhibitory concentration: 51100 nM
Beside the measured number, compound 4's estimate is 1.1-fold (0.03 log units) above it; the measured number falls inside the stated range.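

On the core of compound 3, replacing 4-chlorophenyl with 4-bromophenyl gives a 1.0-fold lower number from compound 3 to compound 4 (0.02 log units; within the scatter), so in this assay chloro and bromo at this place cannot be told apart on this core. The same change on the core of compound 1 cannot be read, because compound 1 and compound 2 both stand at a limit of the assay and not at a number: the limit of > 100000 nM in this assay, at which 2 of the 4 values shown sit. This leaves a single readable case of the change with no second case to set it against, so the result describes one core only and does not show that the size of the step carries over from one core to the other.

Only chloro and bromo appear at this place among the compounds shown, so it remains open how a group of a different kind there, such as an amine, a carboxylic acid or a longer chain, would read in this assay. The two cores also differ in more than one place, so no pair shown here tells which part of that difference goes with compound 3 and compound 4 giving full numbers.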